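A few compounds are considered here, and "the series" means these few. Any claim that something is new, unique, unknown or untested is made for them only; others in the source may bear on it.

In a functional assay on L1210 cells (Mus musculus) for antiproliferative activity, with a stated time of 48 h (a lower number here means a stronger inhibitor, a higher number a weaker inhibitor), three compounds that share one core and differ only in a single halogen have been measured. Compound 1 `Nc1ccc(/C=C/C(=O)c2ccc(F)cc2)cc1`, carrying fluoro, gives 123000 nM. Compound 2 `Nc1ccc(/C=C/C(=O)c2ccc(Cl)cc2)cc1`, carrying chloro, gives 111000 nM. Compound 3 `Nc1ccc(/C=C/C(=O)c2ccc(I)cc2)cc1`, carrying iodo, gives 50000 nM, the lowest number of the three and the strongest inhibitor among them.

The next compound is compound 4 `Cc1ccc(C(=O)/C=C/c2ccc(N)cc2)cc1`, which has methyl in place of iodo on an aromatic carbon, para to a large group: methyl in place of iodo on an aromatic carbon.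

Among the measured compounds shown here, three measured steps bear on this change. Chloro in place of fluoro gives a 1.1-fold lower number from compound 1 to compound 2 (0.04 log units; within the scatter). Iodo in place of fluoro gives a 2.5-fold lower number from compound 1 to compound 3 (0.39 log units; beyond the scatter), and iodo in place of chloro gives a 2.2-fold lower number from compound 2 to compound 3 (0.35 log units; beyond the scatter). Both iodo steps are modest. For the measured compounds named here, none of the measured compounds carries methyl, so the data hold no direct measure of that group. Compound 4 gives up the iodo of compound 3, and the reasoning rests on the modest 2.2-fold lower number from compound 2 to compound 3 (0.35 log units; beyond the scatter). A modest move back towards the numbers of compound 1 and compound 2 is therefore expected. The expected step is a 1.8-fold higher number from compound 3 to compound 4 (0.26 log units; within the scatter). For compound 4 the estimate is 90000 nM, with an expected range from 40000 nM to 200000 nM.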

Compound 4, half-maximal inhibitory concentration: 49000 nM
Compound 4: middle estimate off by 1.8-fold (0.26 log units), on the high side; low and high end bracket the measured number.
By their numbers in this assay, from the lowest: compounds 4 and 3 (each within the scatter of the next); then compounds 2 and 1 (each within the scatter of the next).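

In this assay, putting methyl in place of iodo on this aromatic carbon, para to a large group, gives a 1.0-fold lower number from compound 3 to compound 4 (0.01 log units; within the scatter), so the two groups cannot be told apart here. Methyl also stands clear of the two lighter halogens, with a 2.3-fold lower number from compound 2 to compound 4 (0.36 log units; beyond the scatter) and a 2.5-fold lower number from compound 1 to compound 4 (0.40 log units; beyond the scatter), both modest steps of nearly the same size as those iodo gave; the earlier compounds could suggest that the lower number was tied to iodo alone, but among these four compounds it is not confined to a halogen, and a group holding no halogen at all reaches it too. Nothing available here accounts for why methyl and iodo match or why both part from fluoro and chloro.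

Going by these compounds, it remains open whether a longer chain such as ethyl, or groups such as methoxy or trifluoromethyl, would fall with compound 3 and compound 4 or with the fluoro and chloro compounds at this position. These compounds also vary this one place only, so they leave open how the amine or the carbonyl of the shared core bears on the numbers.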